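This account rests on a few compounds, and the source may have more. Where it says the series, first, only, none or still open, it means among the compounds named here.

Compound 1 `COc1ccc(Br)cc1CCc1c(Cl)cccc1-c1nccn1C(C)C`, in an assay on isolated protein for binding affinity to Melanocortin receptor 4 (Homo sapiens) (a lower number here means a stronger inhibitor, a higher number a weaker inhibitor), compound 1 gives 670 nM.
Compound 2 `Cn1ccnc1-c1cccc(Cl)c1CCc1cc(Br)ccc1O`, in this assay compound 2 gives 9300 nM.

Of the two measured compounds, compound 1 stands at the lower number, and the gap to compound 2 lies beyond the scatter. Compound 3 `COc1ccc(Br)cc1CCc1c(Cl)cccc1-c1ncc2n1CCC2` has not been measured. It differs from compound 1 in one place: a group of 8 heavy atoms (6 carbon, 2 nitrogen; one five-membered non-aromatic ring with 1 hetero atom, one five-membered aromatic ring with 2 hetero atoms) in place of a group of 8 heavy atoms (6 carbon, 2 nitrogen; one five-membered aromatic ring with 2 hetero atoms), on an aromatic carbon. Going by the values given here, no step between measured compounds is available to weigh this change; the only comparison on record, between compound 1 and compound 2, concerns other parts of the molecule and says nothing about this one. The change keeps the count of heavy atoms and acceptors and closes the substituent into a second ring. The expected step from compound 1 to compound 3 is a 1.2-fold higher number from compound 1 to compound 3 (0.08 log units; within the scatter), small and not beyond the scatter. Compound 3 is estimated at 800 nM, with a range from 250 nM to 2500 nM.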

Compound 3, inhibition constant: 180 nM
Beside the measured number, compound 3's estimate is 4.4-fold (0.65 log units) above it; the measured number lies below the stated range.
By their numbers in this assay, from the lowest: compound 3; then compound 1; then compound 2.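

Exchanging 1-isopropyl-1H-imidazol-2-yl for the group closed into a second ring gives, in this assay, a 3.7-fold lower number from compound 1 to compound 3 (0.57 log units; beyond the scatter), a modest step. The position, on an aromatic carbon ortho to a large group and meta to a chloro group, therefore responds to how the atoms are arranged, since the counts of heavy atoms, donors and acceptors stay the same in both groups. Nothing measured in the series accounts for this step.

Still open, from the compounds shown here alone, is whether a six-membered non-aromatic ring in place of the five-membered one, or an amine or a carboxylic acid on the closed ring, would lower the number further. Also open, going by these compounds, is whether the ring closure gives a similar step with a hydroxy group in place of the methoxy group on the bromo-substituted ring.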